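Imidazolyl for imidazolinyl on two related cores

A few compounds are considered here, and "the series" means these few. Any claim that something is new, unique, unknown or untested is made for them only; others in the source may bear on it.

Compound 1 `c1ccc(-c2ccno2)c(OCC2=NCCN2)c1`: 91%
Compound 2 `c1ccc(-c2ccno2)c(OCc2c[nH]cn2)c1`: 91%
Compound 3 `c1ccc(-c2cnco2)c(NCC2=NCCN2)c1`: 107%

In a functional assay for activation of Alpha-1A adrenergic receptor (Homo sapiens) (on this read-out higher numbers stand for larger maximal responses and lower numbers for smaller maximal responses), compound 1 gives 91% and compound 2 gives 91%. The change between them is a group of 5 heavy atoms (3 carbon, 2 nitrogen; one five-membered aromatic ring with 2 hetero atoms) in place of a group of 5 heavy atoms (3 carbon, 2 nitrogen; one five-membered non-aromatic ring with 2 hetero atoms), on a saturated chain carbon bound to an oxygen on an aromatic ring and its step is no change at the digits printed from compound 1 to compound 2 (within the scatter). Compound 3 stands at 107%, the highest of the three numbers, beyond the scatter from compound 1 and from compound 2 alike. The core of compound 3 differs from the core of compound 1 in more than one place, and the difference between the two cores is not broken down here.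

Compound 4 `c1ccc(-c2cnco2)c(NCc2c[nH]cn2)c1` is not yet measured. It arises from compound 3 by a group of 5 heavy atoms (3 carbon, 2 nitrogen; one five-membered aromatic ring with 2 hetero atoms) in place of a group of 5 heavy atoms (3 carbon, 2 nitrogen; one five-membered non-aromatic ring with 2 hetero atoms), on a saturated chain carbon bound to a nitrogen on an aromatic ring. This is the same kind of change as that from compound 1 to compound 2, but the place is not the same: there the carbon is bound to an oxygen on an aromatic ring, here to a nitrogen on an aromatic ring. Since the step from compound 1 to compound 2 was no change at the digits printed from compound 1 to compound 2 (within the scatter), the step expected from compound 3 to compound 4 is a number 2 percentage points lower from compound 3 to compound 4 (within the scatter). For compound 4 the estimate is 105%, expected between 90% and 120%.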

Compound 4, largest response reached (reported as maximum), in percent of the reference or control that the assay uses: 120%
For compound 4 the middle estimate is 15 percentage points below the measured one; measured number inside the range.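

In this assay, putting 1H-imidazol-4-yl in place of the non-aromatic ring gives a number 13 percentage points higher from compound 3 to compound 4 (beyond the scatter), whereas on the other core the same change gave no change at the digits printed from compound 1 to compound 2 (within the scatter). Set side by side, the two steps cannot be told apart: the same change on two cores in this assay, no change at the digits printed (within the scatter) from compound 1 to compound 2 and a number 13 percentage points higher (beyond the scatter) from compound 3 to compound 4, 13 percentage points apart, within the scatter of two such steps. The change therefore carries from the core of compound 1 to the core of compound 3 with no difference these numbers can establish, but this does not show that the two steps are equal, and two cores say nothing about how the change would behave on a further core.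

The compounds shown leave open how much of the gap between the two cores belongs to each place in which they differ, as no pair here separates those places. Also open, going by these compounds, is whether a longer chain carrying the 1H-imidazol-4-yl, or an open-chain amine in its place, would give a similar maximal response.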